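The source may hold more compounds than are shown below. What is called first, only, known or untested is meant among the compounds shown, and "the series" means these compounds.

Compound 1, `CC(C)N(Cc1cccc(OCCCCCC(=O)O)c1)C(=O)c1ccc(-c2cccc(-c3ccccc3)c2)cc1`, gives > 26000 nM in an ADME assay on Raji cells (Homo sapiens) for cytotoxicity, read by CellTiter-Glo and resazurin assay, with a stated time of 72 h; a lower number here means that less compound is needed, a higher number that more compound is needed for the effect; that number is a limit of the assay.
Compound 2, `CCOc1cccc(-c2ccc(C(=O)N(Cc3cccc(OCCCCCC(=O)O)c3)C(C)C)cc2)c1`, gives > 20800 nM in this assay; that number too is a limit.

Within the data shown here, compound 1 therefore stands only at a limit in this assay, and the one further value shown is also a limit. Among the measured compounds shown here, the single measured step, a step that the two limits leave unreadable from compound 1 to compound 2, cannot be read in size because the limit of > 20800 nM in this assay, at which 1 of the 2 values shown sits, and the limit of > 26000 nM in this assay, at which 1 of the 2 values shown sits, mark both of its ends. Compound 3, `CC(C)N(Cc1cccc(OCCCCCC(=O)O)c1)C(=O)c1ccc(-c2cccc(C(F)(F)F)c2)cc1`, differs from compound 1 by trifluoromethyl in place of phenyl on an aromatic carbon. For the measured compounds named here, no measured step gives a readable size, so the expectation for compound 3 is again a limit rather than a number. Compound 3 is estimated at 26000 nM, between 12000 nM and 60000 nM. The expected step is a number no higher from compound 1 to compound 3 (the limit leaves the size open).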

Compound 3, half-maximal effective concentration: > 26000 nM
Compound 3 gave a limit, no number; the forecaster's own chance of this, stated with the estimate: 85%; the middle value lies on the limit itself.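

Compound 3 stands at a limit, as do compound 1 and compound 2, so the steps from compound 1 and from compound 2 to compound 3 cannot be read in size. The compounds shown leave open whether any of these three group exchanges changes the value in this assay at all.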